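Dropping the methoxy from compound 3

The compounds below may be only part of what the source reports. "The series", "measured", "known", "first", "only" and "open" are said of these compounds alone.

Compound 3 `COc1ccc2[nH]c(=O)c(-c3nc4cc(Cl)ccc4[nH]3)cc2c1` gives in a functional assay on HepG2 cells (Homo sapiens) for cytotoxicity, read by MTT assay, with a stated time of 48 h (a higher number here means a weaker inhibitor, a lower number a stronger inhibitor), only the limit of > 100000 nM, so it stands at the weak edge of what was measured. Its fluoro relative, compound 1 `COc1ccc2[nH]c(=O)c(-c3nc4cc(F)ccc4[nH]3)cc2c1`, also gives only the limit of > 100000 nM in this assay, and the step that the two limits leave unreadable from compound 1 to compound 3 is therefore unreadable, as the limit of > 100000 nM in this assay, at which 2 of the 3 values shown sit, shows. Compound 2 `O=c1[nH]c2ccccc2cc1-c1nc2cc(F)ccc2[nH]1` gives 15200 nM in this assay, and the step of an at least 6.5-fold lower number from compound 1 to compound 2 (0.81 log units; beyond the scatter) is the one that bears on the present change. Compound 4 `O=c1[nH]c2ccccc2cc1-c1nc2cc(Cl)ccc2[nH]1` differs from compound 3 by hydrogen in place of methoxy on an aromatic carbon. A drop of comparable size is expected here, since an at least 6.5-fold lower number from compound 1 to compound 2 (0.81 log units; beyond the scatter) came from the same removal. Compound 4 is therefore expected to give 15000 nM in this assay, within 3000 nM to 80000 nM. The expected step is an at least 6.6-fold lower number from compound 3 to compound 4 (0.82 log units; beyond the scatter).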

Compound 4, half-maximal inhibitory concentration: 8450 nM
For compound 4 the middle estimate is 1.8-fold (0.25 log units) above the measured one; low and high end bracket the measured number.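

Removing the methoxy also reads with chloro on the other ring, giving an at least 11-fold lower number from compound 3 to compound 4 (1.07 log units; beyond the scatter) in this assay, so the shift is not confined to the fluoro pair: the same change on two cores in this assay, an at least 6.5-fold lower number (0.81 log units; beyond the scatter) from compound 1 to compound 2 and an at least 11-fold lower number (1.07 log units; beyond the scatter) from compound 3 to compound 4; the limit leaves it open whether they differ. Going by these compounds alone, with hydrogen at this position, the swap of fluoro for chloro becomes readable for the first time, giving a 1.8-fold lower number from compound 2 to compound 4 (0.25 log units; within the scatter), so the two halogens are not told apart here, whereas the methoxy pair's step cannot be read.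

The compounds shown leave open what an amine or a hydroxyl on this aromatic carbon would give. Going by these compounds, the exact size of both methoxy steps also stays open, as each starts from a limit.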